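The source may report more compounds than this note shows. Statements on the series, on what has been measured and on what is new or still open speak of the compounds shown alone.

Working notes on the coumarin-derived sulfonamide pair and the next analogue.

Compound 1 `NS(=O)(=O)c1ccc(/N=C/c2c(Cl)c3ccccc3oc2=O)cc1` is the reference point. Within the data shown here, in a functional assay on MCF7 cells (Homo sapiens) for cytotoxicity, read by CCK-8 assay, with a stated time of 48 h (a lower number here means a stronger inhibitor, a higher number a weaker inhibitor), compound 1 gives 120 nM, the lowest of the two numbers so far; its nearest neighbour is compound 2 `O=c1oc2ccccc2c(Cl)c1/C=N/c1ccc(S(=O)(=O)Nc2nccs2)cc1`, which in this assay gives 160 nM. Among the measured compounds shown here, the only measured step in the set, a 1.3-fold higher number from compound 1 to compound 2 (0.12 log units; within the scatter), is the swap of a ring onto the sulfonamide nitrogen, and it did not move the number beyond the scatter, so compound 1 and compound 2 cannot be ordered.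

Compound 3 `Cc1cc(NS(=O)(=O)c2ccc(/N=C/c3c(Cl)c4ccccc4oc3=O)cc2)no1` has not yet been measured in this assay. Its difference from compound 1 is 5-methyl-1,2-oxazol-3-yl in place of hydrogen on a sulfonamide nitrogen. The step from compound 1 to compound 2 bears directly on this: the same sulfonamide hydrogen was replaced there by a five-membered aromatic ring with two hetero atoms, and a 1.3-fold higher number from compound 1 to compound 2 (0.12 log units; within the scatter) stayed within the scatter. On that single precedent no step beyond the scatter is expected in this assay for compound 3, in either direction, so the estimated step is a 1.3-fold higher number from compound 1 to compound 3 (0.10 log units; within the scatter). Compound 3 is therefore estimated at 150 nM, with a range from 60 nM to 400 nM.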

Compound 3, half-maximal inhibitory concentration: 12 nM
Beside the measured number, compound 3's estimate is 13-fold (1.10 log units) above it, outside the stated range (below it).
By their numbers in this assay, from the lowest: compound 3; then compounds 1 and 2 (each within the scatter of the next).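

The sulfonamide nitrogen is not indifferent to substitution in this assay: 5-methyl-1,2-oxazol-3-yl in place of hydrogen gives a 10-fold lower number from compound 1 to compound 3 (1.00 log units; beyond the scatter), a step beyond the scatter, whereas the earlier ring swap gave only a 1.3-fold higher number from compound 1 to compound 2 (0.12 log units; within the scatter) and left open whether this position could move the number at all. The identity of the ring matters, not just its presence, since two groups that each carry one five-membered aromatic ring with 2 hetero atoms are separated by a 13-fold lower number from compound 2 to compound 3 (1.12 log units; beyond the scatter), and compound 3 is the strongest inhibitor of the three, with its steps to both others beyond the scatter. Nothing at hand gives a reason for this gap between the two rings.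

The two rings differ both in their ring atoms and in the methyl group, so these compounds do not show which of the two carries the step; an unsubstituted 1,2-oxazol-3-yl or a 1,3-thiazol-2-yl bearing a methyl group on the same nitrogen would separate them. Also open, going by these compounds, is whether a non-aromatic substituent on that nitrogen, such as an acetyl group or a short alkyl chain, would give a step of similar size.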